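Removing a tert-butyl from the benzyl group: compound 4

This account rests on a few compounds, and the source may have more. Where it says the series, first, only, none or still open, it means among the compounds named here.

Measured so far:
compound 1 `CC(C)(C)c1ccc(CN2C(=O)S/C(=C\c3ccc(N)cc3)C2=O)cc1` — 53000 nM
compound 2 `C=C(Br)C(=O)Nc1ccc(/C=C2\SC(=O)N(Cc3cccc(Cl)c3)C2=O)cc1` — 8900 nM
compound 3 `CC(C)(C)c1ccc(CN2C(=O)S/C(=C\c3cccc(N)c3)C2=O)cc1` — 145000 nM

Of the compounds shown here, three share one core and have been tested in a functional assay on HeLa cells (Homo sapiens) for cytotoxicity, read by cell counting, with a stated time of 4 days; a higher number here means a weaker inhibitor, a lower number a stronger inhibitor. Compound 3 gives the highest number of the three, 145000 nM; it is therefore the weakest inhibitor shown, and compound 1 with 53000 nM is its nearest neighbour, while compound 2 with 8900 nM lies furthest away. Among the measured compounds shown here, the one measured step within this set, a 2.7-fold higher number from compound 1 to compound 3 (0.44 log units; beyond the scatter), concerns only where the amino group sits on its ring.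

Compound 4 `Nc1cccc(/C=C2\SC(=O)N(Cc3ccccc3)C2=O)c1` is compound 3 with a single change: hydrogen in place of tert-butyl on an aromatic carbon. For the measured compounds named here, no measured step in this set touches the tert-butyl group or the benzyl ring it sits on, so there is no direct guide to the size or direction of the move from compound 3 to compound 4 in this assay. Without such a guide, the expected step of no change at the digits printed from compound 3 to compound 4 (within the scatter) is none beyond the scatter, though the range must be left wide. The estimate for compound 4 is therefore 145000 nM, expected to fall between 50000 nM and 400000 nM.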

Compound 4, half-maximal inhibitory concentration: > 250000 nM
Compound 4: no number, only a limit; the forecaster's own chance of this, stated with the estimate: 15%; at least 1.7-fold (0.23 log units) between middle value and limit.
By their numbers in this assay, from the lowest: compound 2; then compound 1; then compound 3. At a limit, above all of these: compound 4.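

In this assay compound 4 gives > 250000 nM, which is a limit of the assay and not a number: the limit of > 250000 nM in this assay, at which 1 of the 4 values shown sits.

Hydrogen in place of tert-butyl gives an at least 1.7-fold higher number from compound 3 to compound 4 (0.23 log units; that floor lies within the scatter), the first measured step at this place on the benzyl ring, since the earlier step concerned only the amino group on the other ring. It shows that taking away the tert-butyl brings no gain in strength as an inhibitor here, although the result fits anything from a change lost in the scatter to a much larger loss, so it gives a direction that cannot be excluded rather than a measured size.

The compounds shown leave open whether a group of intermediate size at the same place, such as methyl or isopropyl, would give a readable number, and whether a carboxylic acid there would move the number the other way. They also leave open whether the same change would act in the same way on compound 1, which carries a 4-aminophenyl group instead of a 3-aminophenyl group.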